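Cytotoxicity notes: nitro in place of methyl

The source may report more compounds than this note shows. Statements on the series, on what has been measured and on what is new or still open speak of the compounds shown alone.

Compound 1 `C/C(=C\c1cc(-c2ccc(C)cc2)cs1)C(N)=O` carries a methyl group on the six-membered ring attached to the shared core. In a functional assay on T-24 cells (Homo sapiens) for cytotoxicity, read by CCK-8 assay, with a stated time of 24 h (on this read-out lower numbers stand for stronger inhibition and higher numbers for weaker inhibition), compound 1 gives > 50000 nM, which is a limit of the assay rather than a number. Compound 2 `C/C(=C\c1nc(-c2ccccc2)cs1)C(N)=O` is the other measured member of the set. In this assay compound 2 gives > 50000 nM, again a limit and not a number. Among the compounds with values here, compound 1 thus stands at the limit of > 50000 nM in this assay, at which 2 of the 2 values shown sit, so no order between the two measured compounds can be read, and no measured step between compounds that differ in one place exists here.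

Compound 3 `C/C(=C\c1cc(-c2ccc([N+](=O)[O-])cc2)cs1)C(N)=O` is not yet measured. It differs from compound 1 by nitro in place of methyl on an aromatic carbon. Within the data shown here, with both measured values sitting at the limit, there is no measured step to lean on for the direction of this change. The expected step is a number no higher from compound 1 to compound 3 (the limit leaves the size open), none beyond the scatter. Compound 3 is estimated at 50000 nM, within a range of 20000 nM to 100000 nM. Compound 3 is expected most likely to return only a limit again in this assay.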

Compound 3, half-maximal inhibitory concentration: > 50000 nM
Compound 3: no number, only a limit (the forecaster's own chance of this, stated with the estimate: 80%); the middle value sits exactly at the limit.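

Nitro in place of methyl gives no readable step between compound 1 and compound 3 in this assay, since both compounds sit at a limit of the assay rather than at a number: the limit of > 50000 nM in this assay, at which 3 of the 3 values shown sit. The compounds shown leave open whether any member of the series reaches a measurable value in this assay, and how nitro compares with methyl there.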